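The source may hold more compounds than are shown below. What is called first, only, known or untested is meant among the compounds shown, and "the series" means these compounds.

Of the compounds shown here, three built on a shared core have been measured in a functional assay on HCC827 cells (Homo sapiens) for antiproliferative activity, read by MTT assay, with a stated time of 72 h; on this read-out higher numbers stand for weaker inhibition and lower numbers for stronger inhibition. Compound 1 (`CN1CCN(c2ccc(Nc3ncc4nc([S+]([O-])c5ccccc5)n(CC5CC5)c4n3)cc2)CC1`) gives 838 nM, compound 2 (`CN1CCN(c2ccc(Nc3ncc4nc(Sc5ccccc5)n(C5CCCC5)c4n3)cc2)CC1`) gives 51.2 nM, and compound 3 (`CN1CCN(c2ccc(Nc3ncc4nc(Sc5ccccc5)n(C5CC5)c4n3)cc2)CC1`) gives 305 nM. Compound 3 therefore has the second highest of the three numbers, with compound 1 above it and compound 2 below it, and both gaps lie beyond the scatter.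

The next structure is compound 4 (`CN1CCN(c2ccc(Nc3ncc4nc(Sc5ccccc5)n(CC5CC5)c4n3)cc2)CC1`), which has cyclopropylmethyl in place of cyclopropyl on an aromatic nitrogen. Within the data shown here, only one measured step bears directly on this nitrogen: a 6.0-fold higher number from compound 2 to compound 3 (0.78 log units; beyond the scatter), a modest change beyond the scatter, with cyclopropyl replacing cyclopentyl. Cyclopropylmethyl is the larger of the two groups exchanged here, but it is not cyclopentyl, so a partial move back toward compound 2 seems reasonable. A single step establishes no pattern, however. Among the measured compounds shown here, compound 1 already carries cyclopropylmethyl, but it differs from compound 4 at the sulfur, and no measured step isolates that difference.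

A lower number than that of compound 3 is therefore expected, with a shift smaller than the measured step. The expected change is a 2.2-fold lower number from compound 3 to compound 4 (0.34 log units; beyond the scatter). Compound 4 is estimated at 140 nM, within an expected range of 50 nM to 400 nM.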

Compound 4, half-maximal inhibitory concentration: 660 nM
Compound 4: middle estimate off by 4.7-fold (0.67 log units), on the low side, and the stated range ends below it.
By their numbers in this assay, from the lowest: compound 2; then compound 3; then compounds 4 and 1 (each within the scatter of the next).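

In this assay, a group with more heavy atoms on the aromatic nitrogen did not move the number toward that of compound 2: cyclopropylmethyl in place of cyclopropyl gives a 2.2-fold higher number from compound 3 to compound 4 (0.34 log units; beyond the scatter). The comparison with cyclopentyl gives a 13-fold higher number from compound 2 to compound 4 (1.11 log units; beyond the scatter), so across these three compounds, the two groups carrying a three-membered ring both stand apart from cyclopentyl, and heavy-atom count alone does not order the three groups. At the aromatic carbon, the exchange of the oxygen-bearing sulfur group for phenylsulfanyl reads as a 1.3-fold lower number from compound 1 to compound 4 (0.10 log units; within the scatter), so with cyclopropylmethyl on the nitrogen, this pair shows no separation between the two groups.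

Nothing available here accounts for the order of the groups on the nitrogen. The compounds shown leave open how cyclobutyl, cyclohexyl, an open chain such as isobutyl, or a ring bearing an amine such as piperidin-4-yl would read at this nitrogen, and whether the oxygen on sulfur would remain without a separable step if cyclopentyl stood on the nitrogen instead.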